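From hydroxy to chloro: what happens to compound 2?

A few compounds are considered here, and "the series" means these few. Any claim that something is new, unique, unknown or untested is made for them only; others in the source may bear on it.

Measured in a functional assay on KYSE-450 cells (Homo sapiens) for inhibition, read by MTT assay, with a stated time of 48 h; on this read-out higher numbers stand for weaker inhibition and lower numbers for stronger inhibition:
Compound 1 `C/C=C/C(=O)N(Cc1cccc(O)c1)c1cc(OC)c(OC)c(OC)c1`: 14700 nM
Compound 2 `C/C=C/C(=O)N(Cc1ccc(OC)c(O)c1)c1cc(OC)c(OC)c(OC)c1`: 67 nM

Compound 2 has the lower of the two numbers, which means the stronger inhibition. Going by the values given here, the only measured step is a 220-fold lower number from compound 1 to compound 2 (2.34 log units; beyond the scatter), with methoxy in place of hydrogen on an aromatic carbon.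

Compound 3 `C/C=C/C(=O)N(Cc1ccc(OC)c(Cl)c1)c1cc(OC)c(OC)c(OC)c1` keeps that methoxy group and alters another: chloro in place of hydroxy on an aromatic carbon. Put simply, 3-hydroxy-4-methoxyphenyl becomes 3-chloro-4-methoxyphenyl.

Among the compounds with values here, no measured step replaces the hydroxy, so the evidence is only indirect. The methoxy group added in a 220-fold lower number from compound 1 to compound 2 (2.34 log units; beyond the scatter) remains in compound 3, so a loss of that size is not expected. Still, compound 2 at 67 nM is the only measured reference with this methoxy group, and it leaves much room for a rise. A moderate move towards weaker inhibition is therefore expected in this assay, with wide uncertainty. The expected change is a 5.2-fold higher number from compound 2 to compound 3 (0.72 log units; beyond the scatter). Compound 3 is estimated at 350 nM, with an expected range from 70 nM to 2500 nM.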

Compound 3, half-maximal inhibitory concentration: 10100 nM
Compound 3: middle estimate off by 29-fold (1.46 log units), on the low side; measured number outside the range, above it.
By their numbers in this assay, from the lowest: compound 2; then compounds 3 and 1 (each within the scatter of the next).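

In this assay, the hydroxy group of compound 2 turns out to matter as much as the methoxy group did: chloro in its place gives a 150-fold higher number from compound 2 to compound 3 (2.18 log units; beyond the scatter), a large loss of inhibition even though the methoxy group stays. Set beside a 220-fold lower number from compound 1 to compound 2 (2.34 log units; beyond the scatter), this means that among these three compounds the low number appears only when hydroxy and methoxy are present together, since compound 1 has only the hydroxy and compound 3 has only the methoxy, and the two sit together in the 3-hydroxy-4-methoxyphenyl group, with a 1.5-fold lower number from compound 1 to compound 3 (0.16 log units; within the scatter) showing that these two compounds cannot be told apart in this assay. Nothing measured here explains why this single change has such a large effect, so the data cannot say what the hydroxy group contributes.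

From the compounds shown here alone, whether another group in this place, such as an amine, fluoro or methyl, could keep compound 2 at 67 nM remains open. Going by these compounds, it is equally open whether an ethoxy group or a longer chain could take the place of the methoxy group without a similar loss.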